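The source may hold more compounds than are shown below. What is called first, only, known or untested is meant among the compounds shown, and "the series" means these compounds.

Among the compounds with values here, in a functional assay on SiHa cells (Homo sapiens) for inhibition (on this read-out higher numbers stand for weaker inhibition and lower numbers for stronger inhibition), two amides sharing one core have numbers so far. Compound 1 (`COc1cc(/C=C/C(=O)c2cccc(NC(=O)C(C)C)c2)ccc1O`) gives 5.96 ug/mL, and compound 2 (`COc1cc(/C=C/C(=O)c2cccc(NC(=O)c3ccccc3)c2)ccc1O`) gives 4.57 ug/mL, so compound 2 stands level with compound 1 within the scatter.

The next structure, compound 3 (`CCOC(=O)C(=O)Nc1cccc(C(=O)/C=C/c2ccc(O)c(OC)c2)c1`), keeps the shared core and alters only the group on the carbonyl carbon whose other neighbour is the amide-type nitrogen, with ethoxycarbonyl in place of phenyl on a carbonyl carbon.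

Within the data shown here, only one measured step bears on this change. It touches the same carbonyl carbon, with phenyl in place of isopropyl, and amounts to a 1.3-fold lower number from compound 1 to compound 2 (0.12 log units; within the scatter). That single step stays within the scatter, and neither of its groups is ethoxycarbonyl, so it offers only weak guidance and gives no direction for the new group. No step beyond the scatter is therefore expected in this assay, though the range must stay wide. The estimated step is a 1.2-fold higher number from compound 2 to compound 3 (0.08 log units; within the scatter). For compound 3 the expected value is 5.5 ug/mL, with an estimated range from 2.5 ug/mL to 12 ug/mL.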

Compound 3, half-maximal inhibitory concentration: > 50 ug/mL
Compound 3: a limit, no number; the forecaster's own chance of this, stated with the estimate: 5%; middle value at least 9.0-fold (0.95 log units) away from the limit.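

Compound 3 gives a limit and no number in this assay: the limit of > 50 ug/mL in this assay, at which 1 of the 3 values shown sits.

Even so, the steps can be read, and they show that the carbonyl carbon whose other neighbour is the amide-type nitrogen does respond to its substituent, with an at least 10-fold higher number from compound 2 to compound 3 (1.03 log units; beyond the scatter) and an at least 8.3-fold higher number from compound 1 to compound 3 (0.92 log units; beyond the scatter). The earlier exchange of isopropyl for phenyl had stayed within the scatter, so this position had shown no sensitivity until ethoxycarbonyl entered, and the loss holds against both a ring-bearing group and one without a ring.

From the compounds shown here alone, how far the true number of compound 3 lies past its limit remains unknown, and these three compounds cannot tell whether the change follows from the oxygen atoms of ethoxycarbonyl, its hydrogen-bond acceptors or its chain. Also open, going by these compounds, is whether a carboxylic acid, an amine or a plain longer carbon chain on this same carbonyl carbon would stay level with compound 1 and compound 2 or fall away as compound 3 does.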